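Swapping the Aryl Group on the Carbonyl of Compound 3

The source may report more compounds than this note shows. Statements on the series, on what has been measured and on what is new or still open speak of the compounds shown alone.

Compound 1 `O=C(NNc1cccc(Cl)c1)c1ccc(NS(=O)(=O)c2cnc(O)nc2O)cc1` gives 7290 nM.
Compound 2 `O=C(NNc1ccc(F)cc1)c1ccc(NS(=O)(=O)c2cnc(O)nc2O)cc1` gives > 20000 nM, which is a limit of the assay.
Compound 3 `Cc1ccc(C(=O)NNC(=O)c2ccc(NS(=O)(=O)c3cnc(O)nc3O)cc2)cc1` gives 15900 nM.

All three were tested in a functional assay on A549 cells (Homo sapiens) for antiproliferative activity, read by MTT assay, with a stated time of 24 h; a lower number here means a stronger inhibitor, a higher number a weaker inhibitor. Compound 3 holds the higher of the two true numbers, and its nearest neighbour gives the step of a 2.2-fold higher number from compound 1 to compound 3 (0.34 log units; beyond the scatter). Compound 4 `O=C(NNC(=O)c1ccccc1Cl)c1ccc(NS(=O)(=O)c2cnc(O)nc2O)cc1` carries one change, 2-chlorophenyl in place of 4-methylphenyl on a carbonyl carbon. Among the measured compounds shown here, no measured step makes this swap. The nearest changes sit on an amine nitrogen, namely a 2.2-fold higher number from compound 1 to compound 3 (0.34 log units; beyond the scatter) and an at least 2.7-fold higher number from compound 1 to compound 2 (0.43 log units; beyond the scatter), and both start from the chlorine-bearing compound 1. Only a small downward shift in this assay is therefore expected, probably within the scatter. The expected step runs a 1.3-fold lower number from compound 3 to compound 4 (0.12 log units; within the scatter). For compound 4 the estimated value is 12000 nM, with an expected range of 6000 nM to 20000 nM.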

Compound 4, half-maximal inhibitory concentration: 1900 nM
Estimate against measurement, compound 4: 6.3-fold (0.80 log units) above; the whole stated range lies above it.
By their numbers in this assay, from the lowest: compound 4; then compound 1; then compound 3. At a limit, above all of these: compound 2.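

On a carbonyl carbon, the aryl group matters in this assay: an 8.4-fold lower number from compound 3 to compound 4 (0.92 log units; beyond the scatter), so this position responds strongly to 2-chlorophenyl in place of 4-methylphenyl. The (2-chlorophenyl)carbonyl group on the amine nitrogen also improves on both aryl groups placed there, with a 3.8-fold lower number from compound 1 to compound 4 (0.58 log units; beyond the scatter) and an at least 10-fold lower number from compound 2 to compound 4 (1.02 log units; beyond the scatter). The second of these steps is only a floor, as compound 2 stands at a limit: the limit of > 20000 nM in this assay, at which 1 of the 4 values shown sits.

The compounds shown leave open whether the chlorine or its ring position carries this step. A 4-chlorophenyl or 2-methylphenyl group on the same carbonyl carbon would separate the two.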